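Benzothiazolyl for methoxyphenyl on the triazole-type nitrogen: cytotoxicity outlook

The compounds below may be only part of what the source reports. "The series", "measured", "known", "first", "only" and "open" are said of these compounds alone.

The series shares one core, shown for compound 1 as `COc1cccc(-n2cc(COc3c(/C=C\C(=O)O)ccc(OC)c3CC=C(C)C)nn2)c1`. Going by the values given here, in a functional assay on A549 cells (Homo sapiens) for cytotoxicity, read by MTT assay, with a stated time of 24 h (a lower number here means a stronger inhibitor, a higher number a weaker inhibitor), compound 1 gives 42700 nM, and this is the only number the series has so far. Among the compounds with values here, compound 2, `COc1ccc(/C=C\C(=O)O)c(OCc2cn(-c3cccc(C#N)c3)nn2)c1CC=C(C)C`, is recorded in this assay as "not determined" (no result reported), and compound 3, `COc1ccc(/C=C\C(=O)O)c(OCc2cn(-c3ccc(CO)cc3)nn2)c1CC=C(C)C`, is recorded in this assay as "not determined" (no result reported), so neither carries a number in this assay, compound 1 stands alone as the reference, and no step between measured compounds can be drawn.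

Compound 4 is `COc1ccc(/C=C\C(=O)O)c(OCc2cn(-c3nc4ccccc4s3)nn2)c1CC=C(C)C`. It differs from compound 1 in one place: 1,3-benzothiazol-2-yl in place of 3-methoxyphenyl on an aromatic nitrogen of a five-membered aromatic ring with 3 nitrogen.

With no measured step of this kind in the series, the expectation rests on compound 1 alone. The step from compound 1 to compound 4 in this assay is estimated as a 1.4-fold lower number from compound 1 to compound 4 (0.15 log units; within the scatter), a modest shift toward a lower number that may not exceed the scatter. Compound 4 is accordingly expected to give about 30000 nM in this assay, within a range from 8000 nM to 110000 nM.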

Compound 4, half-maximal inhibitory concentration: 42100 nM
The estimate for compound 4 lay 1.4-fold (0.15 log units) below the measured number, within the range that was stated.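

In this assay, going by these compounds alone, the first step that can be read at this position is a 1.0-fold lower number from compound 1 to compound 4 (0.01 log units; within the scatter), so 1,3-benzothiazol-2-yl and 3-methoxyphenyl on an aromatic nitrogen are not separated by this read-out. The position therefore takes a group with one five-membered aromatic ring with 2 hetero atoms in addition to a six-membered aromatic ring of carbon only, with no difference from compound 1 beyond the scatter. No measurement bears on why the two groups read alike.

Compound 2 and compound 3 carry no number, so their steps cannot be read. Also open, going by these compounds, is whether a plain alkyl chain or an aminomethylphenyl group on this nitrogen would move the number in this assay beyond the scatter.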